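A Larger Group Where Compound 1 Carries Methyl

The source may hold more compounds than are shown below. What is called first, only, known or untested is meant among the compounds shown, and "the series" means these compounds.

Of the compounds shown here, two sharing one core have been measured in a functional assay for agonist activity at Free fatty acid receptor 1 (Homo sapiens); on this read-out lower numbers stand for an effect already at smaller amounts and higher numbers for an effect only at larger amounts of compound. Compound 1 `Cc1ccc(CNc2ccc(CCC(=O)O)cc2)cc1` gives 3980 nM. Compound 2 `O=C(O)CCc1ccc(NCc2ccccc2)cc1` carries hydrogen where compound 1 carries methyl, and compound 2 gives 7940 nM. That single change amounts to a 2.0-fold higher number from compound 1 to compound 2 (0.30 log units; within the scatter), so the two compounds cannot be told apart on this read-out, and compound 2 stands at the higher of the two numbers only in a nominal sense.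

Compound 3 `CN(C)Cc1ccc(CNc2ccc(CCC(=O)O)cc2)cc1` is the next step from compound 2: (dimethylamino)methyl in place of hydrogen on an aromatic carbon. The new group sits on the aromatic carbon that carries hydrogen in compound 2 and methyl in compound 1. Within the data shown here, the only measured step that bears on this position is the one from compound 1 to compound 2, and it stayed within the scatter. Among the measured compounds shown here, nothing measured so far shows that this position is sensitive, and nothing shows how a group larger than methyl behaves there.

Compound 3 is therefore expected to change the number by a 1.8-fold lower number from compound 2 to compound 3 (0.25 log units; within the scatter), which is no more than the scatter. The estimate for compound 3 in this assay is 4500 nM, with a range from 1500 nM to 14000 nM.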

Compound 3, half-maximal effective concentration: < 31700 nM
Compound 3: no number, only a limit (the forecaster's own chance of this, stated with the estimate: 10%); the middle value lies beyond the limit too.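

In this assay compound 3 gives < 31700 nM as a limit of the assay and not a number. The steps from compound 1 and from compound 2 to compound 3 therefore cannot be read. The compounds shown leave open how far compound 3 lies from the other two, and whether a group larger than methyl on that aromatic carbon changes the number at all.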